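A Single Fluoro on Compound 1

The source may report more compounds than this note shows. Statements on the series, on what has been measured and on what is new or still open speak of the compounds shown alone.

Measured so far in an ADME assay on THLE-2 cells (Homo sapiens) for cytotoxicity, read by MTT assay; a lower number here means that less compound is tolerated, a higher number that more compound is tolerated:
- Compound 1 `c1ccc(-c2ccnc3c2c(-c2ccccc2)nn3-c2ccccc2)cc1` gives 34200 nM
- Compound 2 `N#Cc1c(-c2ccc(Cl)cc2)nc2c(c(-c3ccccc3)nn2-c2ccccc2)c1-c1ccc(N2CCCCC2)cc1` gives 12500 nM

Among the compounds with values here, of these two numbers, the one for compound 1 is the higher, and the gap down to compound 2 lies beyond the usual scatter. More of compound 1 is therefore tolerated. Within the data shown here, no two measured compounds differ in one place only, so the data hold no direct precedent for the next change.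

Compound 3 `Fc1ccc(-c2ccnc3c2c(-c2ccccc2)nn3-c2ccccc2)cc1` keeps the core of compound 1 but has fluoro in place of hydrogen on an aromatic carbon, para to a large group. This turns a phenyl into a 4-fluorophenyl. Among the measured compounds shown here, with so small a change and no measured step to guide it, no shift beyond the scatter is expected in either direction, and the expectation stays anchored to compound 1 at 34200 nM as its nearest measured neighbour. The estimated step is a 1.1-fold lower number from compound 1 to compound 3 (0.06 log units; within the scatter) and it is expected to stay within the scatter. The expected value for compound 3 is 30000 nM (range 15000 nM to 60000 nM), with the measurement still to come.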

Compound 3, half-maximal cytotoxic concentration: 19700 nM
Beside the measured number, compound 3's estimate is 1.5-fold (0.18 log units) above it; the range from low to high includes it.
By their numbers in this assay, from the lowest: compounds 2, 3 and 1 (each within the scatter of the next, the first and the last beyond it).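

Within the data shown here, the step from hydrogen to fluoro on an aromatic carbon, para to a large group, gives a 1.7-fold lower number from compound 1 to compound 3 (0.24 log units; within the scatter) in this assay, and it is the first change in these data that can be read at a single place. It shows that turning the phenyl of compound 1 into the 4-fluorophenyl of compound 3 leaves the tolerated concentration indistinguishable from that of compound 1, so this one position accepts a single fluorine atom without a change that stands clear of repeated measurement, something the comparison with compound 2, which differs in several places, could not show. Nothing measured alongside these numbers bears on this result, and the step stands without any account of what lies behind it.

Going by these compounds, what stays open is whether a larger or charged group at this same place, such as a methoxy group, a dimethylamino group or a carboxylic acid, would carry the number beyond the scatter in either direction. On these data alone, it also remains open whether fluoro on the other phenyl rings of the shared core would behave as it does here.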